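Trifluoromethyl in Place of (Dimethylamino)methyl: An Expected Potency

The source may report more compounds than this note shows. Statements on the series, on what has been measured and on what is new or still open speak of the compounds shown alone.

Two compounds have been measured in a functional assay on U2OS cells for antagonist activity at C-X-C chemokine receptor type 3 (Homo sapiens), read by beta-arrestin recruitment; a higher number here means a weaker inhibitor, a lower number a stronger inhibitor:
Compound 1 `C[C@@H]1CN(c2sc(C3CC3)nc2-c2nc3ccccc3[nH]2)CCN1C(=O)Cn1cnc2cccnc21`: 745 nM
Compound 2 `C[C@@H]1CN(c2sc(CN(C)C)nc2-c2nc3ccccc3[nH]2)CCN1C(=O)Cn1cnc2cccnc21`: 2360 nM

Compound 2 stands at the higher of the two numbers; its nearest neighbour, compound 1, gives the lower one by a 3.2-fold higher number from compound 1 to compound 2 (0.50 log units; beyond the scatter). Compound 3 `C[C@@H]1CN(c2sc(C(F)(F)F)nc2-c2nc3ccccc3[nH]2)CCN1C(=O)Cn1cnc2cccnc21` is made from compound 2 by trifluoromethyl in place of (dimethylamino)methyl on an aromatic carbon. Within the data shown here, the only step that bears on this position is the one from compound 1 to compound 2, which was modest. Compound 3 is therefore expected to move back toward compound 1, and its estimated step is a 2.4-fold lower number from compound 2 to compound 3 (0.37 log units; beyond the scatter). Compound 3 is estimated at 1000 nM, within 350 nM to 3000 nM.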

Compound 3, half-maximal inhibitory concentration: 31 nM
Compound 3: the middle estimate sits 32-fold (1.51 log units) above what was measured; the whole stated range lies above it.
By their numbers in this assay, from the lowest: compound 3; then compound 1; then compound 2.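

In this assay trifluoromethyl in place of (dimethylamino)methyl gives a 76-fold lower number from compound 2 to compound 3 (1.88 log units; beyond the scatter) and trifluoromethyl in place of cyclopropyl gives a 24-fold lower number from compound 1 to compound 3 (1.38 log units; beyond the scatter) so it stands clear of both earlier groups. This position therefore carries far more of the potency than the modest step between the first two compounds showed. No measurement at hand explains the gain.

Going by these compounds, whether the gain belongs to trifluoromethyl alone stays open. A chlorine atom, a methyl group or a pentafluoroethyl chain on the same aromatic carbon would bear on that question.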